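This account rests on a few compounds, and the source may have more. Where it says the series, first, only, none or still open, it means among the compounds named here.

The shared core appears in compound 1 `CC(C)Nc1nc2c(nc1N1CCC(Oc3ccc(F)cc3F)CC1)C=CNC2`, compound 2 `CC(C)Nc1nc2c(nc1N1CCC(Oc3ccc(F)cc3F)CC1)C=CN(C)C2` and compound 3 `CC(C)Nc1nc2c(nc1N1CCC(Oc3ccc(F)cc3F)CC1)C=CN(S(C)(=O)=O)C2`, which differ only in the substituent on an amine nitrogen in a ring. In a functional assay on CHO-K1 cells for agonist activity at G-protein coupled receptor 6 (Homo sapiens), read by TR-FRET and cAMP accumulation, with a stated time of 20 h (on this read-out lower numbers stand for an effect already at smaller amounts and higher numbers for an effect only at larger amounts of compound), compound 1 gives 100000 nM, compound 2 gives 89000 nM and compound 3 gives 65000 nM. Compound 3 stands at the low end of these three numbers, yet its separations from the others, a 1.5-fold lower number from compound 1 to compound 3 (0.19 log units; within the scatter) and a 1.4-fold lower number from compound 2 to compound 3 (0.14 log units; within the scatter), are within the scatter, as is a 1.1-fold lower number from compound 1 to compound 2 (0.05 log units; within the scatter). None of the exchanges at this nitrogen has moved the read-out beyond the scatter.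

Compound 4 `COC(=O)N1C=Cc2nc(N3CCC(Oc4ccc(F)cc4F)CC3)c(NC(C)C)nc2C1` continues at the same position: methoxycarbonyl in place of methylsulfonyl on an amine nitrogen in a ring. All three measured steps bear on it, since each replaces one group with another on this nitrogen, and each stayed within the scatter. Among the measured compounds shown here, a methoxycarbonyl has no closer precedent, so nothing on hand points to a step beyond the scatter in either direction in this assay.

Compound 4 is therefore expected to give about 60000 nM, with a range from 30000 nM to 120000 nM. That expectation corresponds to a 1.1-fold lower number from compound 3 to compound 4 (0.03 log units; within the scatter).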

Compound 4, half-maximal effective concentration: 158000 nM
The estimate for compound 4 lay 2.6-fold (0.42 log units) below the measured number; measured number outside the range, above it.
By their numbers in this assay, from the lowest: compounds 3, 2, 1 and 4 (each within the scatter of the next, the first and the last beyond it).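

In this assay, this nitrogen gives its first step beyond the scatter, a 2.4-fold higher number from compound 3 to compound 4 (0.39 log units; beyond the scatter), a modest one, in an exchange of methylsulfonyl for methoxycarbonyl, two groups with equal counts of heavy atoms and hydrogen-bond acceptors that differ in sulfur against carbon and in the number of double bonds. Among the compounds shown here, the other two new steps, a 1.8-fold higher number from compound 2 to compound 4 (0.25 log units; within the scatter) and a 1.6-fold higher number from compound 1 to compound 4 (0.20 log units; within the scatter), remain within the scatter, so the separation rests on the single pair of compound 3 and compound 4, and hydrogen and methyl on this nitrogen are not separated from compound 4. The data therefore show that the choice between these two similarly sized groups can be read in this assay, but they offer no ordering of the whole set, and no measurement on hand explains the step.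

Still open, going by these compounds, is whether an acetyl group, which keeps the carbonyl but lacks the methoxy oxygen, or ethylsulfonyl, with a longer chain on the sulfonyl, would fall with compound 3 or with compound 4. Also open, on these data alone, is whether any group on this nitrogen can move the number well beyond this narrow spread.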